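Swapping a Cyclohexyl for a Furanyl Ethyl Group

A few compounds are considered here, and "the series" means these few. Any claim that something is new, unique, unknown or untested is made for them only; others in the source may bear on it.

Of the compounds shown here, two have been measured so far. In a functional assay on HEK293T cells for agonist activity at histamine H2 receptor (Homo sapiens), read by beta-arrestin recruitment (on this read-out higher numbers stand for an effect only at larger amounts of compound and lower numbers for an effect already at smaller amounts), compound 1 `Cc1nc(N)sc1CCCN/C(N)=N/C(=O)NC1CCCCC1` gives 389 nM, the lower of the two numbers. Compound 2 `N/C(=N\C(=O)NCc1ccccc1)NC1CCc2nc(N)sc2C1` gives 4370 nM in this assay; it differs from compound 1 in more than one place, so its value is only compared, not traced to one change.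

Compound 3 `Cc1nc(N)sc1CCCN/C(N)=N/C(=O)NC(C)c1ccco1` is not yet measured. It differs from compound 1 in a single place: 1-(furan-2-yl)ethyl in place of cyclohexyl on an amide-type nitrogen. Going by the values given here, no measured pair shows what such an exchange does, so the expectation rests on compound 1 alone. The step from compound 1 to compound 3 is expected to be small, likely toward a slightly higher number, a 1.5-fold higher number from compound 1 to compound 3 (0.19 log units; within the scatter), which stays close to the usual scatter. Compound 3 is therefore estimated at about 600 nM, with a likely range from 150 nM to 2500 nM.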

Compound 3, half-maximal effective concentration: 234 nM
Estimate against measurement, compound 3: 2.6-fold (0.41 log units) above; measured number inside the range.
By their numbers in this assay, from the lowest: compounds 3 and 1 (each within the scatter of the next); then compound 2.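

Exchanging cyclohexyl for 1-(furan-2-yl)ethyl on the amide-type nitrogen gives a 1.7-fold lower number from compound 1 to compound 3 (0.22 log units; within the scatter) in this assay, so the two compounds cannot be told apart on this read-out. For this pair, then, a six-membered non-aromatic ring of carbon only and a five-membered aromatic ring with one hetero atom, which also brings one hydrogen-bond acceptor, give values within the usual scatter of each other. No measurement at hand explains this closeness.

The compounds shown leave open whether the furan ring or the ethyl link matters more, as this one exchange alters both together. They also leave open how a simple phenyl group or a longer chain such as n-hexyl would behave on this same nitrogen with the core of compound 1.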